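A few compounds are considered here, and "the series" means these few. Any claim that something is new, unique, unknown or untested is made for them only; others in the source may bear on it.

Measured compounds:
- compound 1, `Cc1cc(CNC(=O)Nc2cc(Cl)nc(OCC(F)F)c2)nnc1-c1cn(C)nc1C(F)(F)F`: 71000 nM
- compound 2, `CCOc1cc(NC(=O)NCc2cc(C)c(-c3cn(C)nc3C(F)(F)F)nn2)cc(C#N)n1`: 67000 nM
- compound 3, `Cc1cc(CNC(=O)Nc2cc(OCC(O)CO)nc(C(F)(F)F)c2)nnc1-c1cn(C)nc1C(F)(F)F`: > 10000000 nM

In a functional assay on HFL1 cells for antagonist activity at sphingosine 1-phosphate receptor 2 (Homo sapiens), read by ELISA, with a stated time of 24 h, in the presence of a further agent that is not named here (a higher number here means a weaker inhibitor, a lower number a stronger inhibitor), compound 2 gives 67000 nM. In this assay compound 1 gives 71000 nM, and the gap between compound 2 and compound 1 lies within the usual scatter, so the two cannot be told apart. For compound 3 the result in this assay is only a limit, > 10000000 nM, and not a number; this is the limit of > 10000000 nM in this assay, at which 1 of the 3 values shown sits. Compound 2 therefore stands with compound 1 as one of the two compounds that returned a number at all.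

Compound 4, `CCOc1nc(Cl)cc(NC(=O)NCc2cc(C)c(-c3cn(C)nc3C(F)(F)F)nn2)c1C`, has not been measured. It differs from compound 2 in one place: 6-chloro-2-ethoxy-3-methylpyridin-4-yl in place of 2-cyano-6-ethoxypyridin-4-yl on an amide-type nitrogen. Going by the values given here, no step between measured compounds covers this kind of change, so nothing gives its direction. Compound 1 carries a chlorine on the same ring type and gives 71000 nM, which speaks for a number near that of compound 2. Compound 4 is expected to give 55000 nM in this assay, within 15000 nM to 250000 nM. The step that this estimate means, a 1.2-fold lower number from compound 2 to compound 4 (0.09 log units; within the scatter), is expected to stay within the scatter.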

Compound 4, half-maximal inhibitory concentration: 32000 nM
Estimate against measurement, compound 4: 1.7-fold (0.24 log units) above; low and high end bracket the measured number.
By their numbers in this assay, from the lowest: compound 4; then compounds 2 and 1 (each within the scatter of the next). At a limit, above all of these: compound 3.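

Going by these compounds alone, with 6-chloro-2-ethoxy-3-methylpyridin-4-yl in place of 2-cyano-6-ethoxypyridin-4-yl on the amide-type nitrogen, this assay shows a 2.1-fold lower number from compound 2 to compound 4 (0.32 log units; beyond the scatter) as the first single-place step, and a modest one. The number at this position therefore moves with the pyridinyl group, but the change replaces the nitrile with a chlorine and adds a methyl at once, so the step cannot be divided between the two. Nothing measured on these compounds accounts for the step.

Open, going by these compounds, is whether the chlorine or the methyl alone would give the same step. Also open, on these data alone, is how the number would respond to an amine or a carboxylic acid on this ring, or to a longer chain in place of the ethoxy group.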